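A few compounds are considered here, and "the series" means these few. Any claim that something is new, unique, unknown or untested is made for them only; others in the source may bear on it.

Compound 1 `CCN(CC)CCNC(=O)Nc1nc2ccc(-c3cnc(OC)c(NS(=O)(=O)c4ccc(F)cc4)c3)cc2s1` is one of three compounds built on a shared core. In a functional assay on HCT-116 cells (Homo sapiens) for antiproliferative activity, read by MTT assay, with a stated time of 72 h (a higher number here means a weaker inhibitor, a lower number a stronger inhibitor), compound 1 gives 300 nM, the lowest of the three numbers, though the gap to compound 3 is within the scatter. Compound 2 `COc1ncc(-c2ccc3nc(NC4CC4)sc3c2)cc1NS(=O)(=O)c1ccc(F)cc1` gives 1560 nM and compound 3 `COc1ncc(-c2ccc3nc(NC(=O)NC4CC4)sc3c2)cc1NS(=O)(=O)c1ccc(F)cc1` gives 470 nM. Compound 4 `CNC(=O)Nc1nc2ccc(-c3cnc(OC)c(NS(=O)(=O)c4ccc(F)cc4)c3)cc2s1` differs from compound 1 by hydrogen in place of (diethylamino)methyl on a saturated chain carbon bound to an amide-type nitrogen. The closest measured guide is the step of a 1.6-fold higher number from compound 1 to compound 3 (0.19 log units; within the scatter), which exchanged the same amine-bearing tail for a small cyclopropyl group. The step of a 5.2-fold higher number from compound 1 to compound 2 (0.72 log units; beyond the scatter) alters the urea itself and bears less on this change. A shift no larger than the scatter is therefore expected, a 1.4-fold higher number from compound 1 to compound 4 (0.15 log units; within the scatter). Compound 4 is expected to give about 420 nM, within a range of 150 nM to 1200 nM.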

Compound 4, half-maximal inhibitory concentration: 870 nM
The estimate for compound 4 lay 2.1-fold (0.32 log units) below the measured number, and the stated range covers the measured number.
By their numbers in this assay, from the lowest: compounds 1, 3, 4 and 2 (each within the scatter of the next, the first and the last beyond it).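

Compound 4 carries methyl where compound 1 carries 2-(diethylamino)ethyl. The step is a 2.9-fold higher number from compound 1 to compound 4 (0.46 log units; beyond the scatter) and so registers at this position, whereas cyclopropyl in compound 3 gave no step beyond the scatter from compound 1. Yet methyl and cyclopropyl themselves cannot be told apart, with a 1.9-fold higher number from compound 3 to compound 4 (0.27 log units; within the scatter) inside the scatter. Methylcarbamoyl in place of cyclopropyl gives only a 1.8-fold lower number from compound 2 to compound 4 (0.25 log units; within the scatter) while a 3.3-fold lower number from compound 2 to compound 3 (0.52 log units; beyond the scatter) lies beyond it, so the carbamoyl step depends on what it carries.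

Nothing available explains these shifts. As far as these compounds go, whether the tail's amine or its length counts stays open, and a plain butyl chain on the same nitrogen would separate the two.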